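This account rests on a few compounds, and the source may have more. Where it says the series, first, only, none or still open, it means among the compounds named here.

Measured so far:
compound 1 `N#CC1=C(N)OC(c2c[nH]c3ccccc23)=C(C#N)C1c1ccccc1F` — "not active" (no number reported)
compound 2 `N#CC1=C(N)OC(c2c[nH]c3ccccc23)=C(C#N)C1c1ccc2ccccc2c1` — "not active" (no number reported)
compound 3 `COc1ccc(C2C(C#N)=C(N)OC(c3c[nH]c4ccccc34)=C2C#N)cc1` — 28.7%

Among the compounds with values here, in a functional assay, tested at 400 ug/mL (on this read-out lower numbers stand for a weaker effect and higher numbers for a stronger effect at the one concentration tested), compound 3 gives 28.7%, the only number in the set; compound 1 gives "not active" (no number reported) and compound 2 gives "not active" (no number reported), with no number in either case. Within the data shown here, no step between measured compounds differing in one place is available, so the size of a single change in this assay is unknown. Compound 4 `N#CC1=C(N)OC(c2c[nH]c3ccccc23)=C(C#N)C1c1ccccc1Cl` is not yet measured. It differs from compound 3 thus: 2-chlorophenyl in place of 4-methoxyphenyl on a saturated ring carbon. Among the measured compounds shown here, the group that leaves is carried by compound 3, whose read-out 28.7% is the only number, while compounds 1 and 2 gave none; a downward step a number 16.7 percentage points lower from compound 3 to compound 4 (beyond the scatter) is therefore expected in this assay, with a fair chance of no number at all. Compound 4 is estimated at 12%, range 0% to 30%.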

Compound 4, a percentage reported as activity, at one concentration (the size of the read-out at that concentration, not a potency): 21.4%
Beside the measured number, compound 4's estimate is 9.4 percentage points below it, within the range that was stated.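

In this assay, 2-chlorophenyl in place of 4-methoxyphenyl on the saturated ring carbon gives a number 7.3 percentage points lower from compound 3 to compound 4 (within the scatter). A number at this position is thus not confined to 4-methoxyphenyl and persists without the hydrogen-bond acceptor counted on that group. Halogen identity may matter, since compound 1, with fluorine in place of the chlorine, gives "not active" (no number reported), although the cause of that contrast is unknown and no supporting measurement explains any of these results. Still open, as far as these compounds go, is whether a phenyl bearing an amine or a carboxylic acid, or a longer chain at this carbon, would give a read-out in this assay.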